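Swapping an aryl for an alkyl tail: tolerance in cells

A few compounds are considered here, and "the series" means these few. Any claim that something is new, unique, unknown or untested is made for them only; others in the source may bear on it.

Measured compounds:
compound 1 `COc1ccc(Cn2ccc3nc(-c4ccccc4)nc-3c2)cc1` — > 100000 nM
compound 2 `CC(c1ccccc1)n1ccc2nc(-c3ccccc3)nc-2c1` — > 100000 nM

In an ADME assay on MDBK cells (Bos taurus) for cytotoxicity (a higher number here means that more compound is tolerated, a lower number that less compound is tolerated), compound 1 gives > 100000 nM, which is a limit of the assay and not a number. In this assay compound 2 gives > 100000 nM, also a limit. Compound 1 therefore stands at the limit of > 100000 nM in this assay, at which 2 of the 2 values shown sit, and nothing beyond that can be read from its value.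

Compound 3 `CC(C)CCn1ccc2nc(-c3ccccc3)nc-2c1` is not yet measured. It differs from compound 1 by isobutyl in place of 4-methoxyphenyl on a saturated chain carbon bound to an aromatic nitrogen. Among the compounds with values here, no step between two measured compounds is available to gauge such a change, so any expectation rests on the two limits alone. The step from compound 1 to compound 3 is expected to be a number no higher from compound 1 to compound 3 (the limit leaves the size open), that is, none beyond the scatter, most likely another limit. For compound 3 the estimate is 100000 nM, with a range from 30000 nM to 300000 nM.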

Compound 3, half-maximal cytotoxic concentration: > 100000 nM
Compound 3: only a limit was reported (the forecaster's own chance of this, stated with the estimate: 75%); the middle value sits exactly at the limit.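

Within the data shown here, compound 1 and compound 3 both stand at a limit of this assay, not at a number, so no step between them can be read: the limit of > 100000 nM in this assay, at which 3 of the 3 values shown sit. The compounds shown leave open where tolerance truly lies for any of them, and whether isobutyl in place of 4-methoxyphenyl changes it at all.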